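Replacing 3,4-dimethoxyphenyl with furan-2-yl in compound 4

The source may report more compounds than this note shows. Statements on the series, on what has been measured and on what is new or still open speak of the compounds shown alone.

Measured in a functional assay on COLO 205 cells (Homo sapiens) for inhibition, read by sulforhodamine B assay, with a stated time of 48 h, tested at 50 uM; a lower number here means less inhibition of growth, a higher number more inhibition of growth at the concentration tested:
- compound 1 `COc1cc(/C=C/C(=O)/C=C/c2cccs2)ccc1OCc1cn(CCOc2cc(=O)oc3ccccc23)nn1`: 66%
- compound 2 `COc1cccc(/C=C/C(=O)/C=C/c2ccc(OCc3cn(CCOc4cc(=O)oc5ccccc45)nn3)c(OC)c2)c1`: 69%
- compound 3 `COc1ccc(/C=C/C(=O)/C=C/c2ccc(OCc3cn(CCOc4cc(=O)oc5ccccc45)nn3)c(OC)c2)cc1OC`: 80%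

Compound 3 stands highest of these three in this assay, and its gaps to both others lie beyond the scatter. Compound 4 `COc1cc(/C=C/C(=O)/C=C/c2ccco2)ccc1OCc1cn(CCOc2cc(=O)oc3ccccc23)nn1` keeps the rest of compound 3 and changes one group: furan-2-yl in place of 3,4-dimethoxyphenyl on a double-bonded chain carbon bound to a double-bonded chain carbon. In short, furan-2-yl takes the place of 3,4-dimethoxyphenyl on a double-bonded chain carbon bound to a double-bonded chain carbon.

Among the compounds with values here, no compound with furan-2-yl has been measured yet, so the nearest guide is thiophen-2-yl at the same place in compound 1. Exchanging that group for 3,4-dimethoxyphenyl gave a number 14 percentage points higher from compound 1 to compound 3 (beyond the scatter). Adding the second methoxy gave a number 11 percentage points higher from compound 2 to compound 3 (beyond the scatter), while exchanging thiophen-2-yl for 3-methoxyphenyl gave only a number 3 percentage points higher from compound 1 to compound 2 (within the scatter). Read in reverse, the first of these steps suggests that leaving 3,4-dimethoxyphenyl for a small ring group should cost a modest amount of growth inhibition. The expected step is a number 14 percentage points lower from compound 3 to compound 4 (beyond the scatter). This rests on a single stand-in, so the range stays wide. For compound 4 the estimated value is 66%, with an expected range from 53% to 79%.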

Compound 4, percent growth inhibition at one concentration: 68%
Compound 4: the middle estimate sits 2 percentage points below what was measured, and the stated range covers the measured number.
By their numbers in this assay, from the lowest: compounds 1, 4 and 2 (each within the scatter of the next); then compound 3.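

In this assay furan-2-yl in place of 3,4-dimethoxyphenyl gives a number 12 percentage points lower from compound 3 to compound 4 (beyond the scatter) and thus shows that the loss seen earlier with thiophen-2-yl at this place recurs with a second five-membered aromatic ring. Furan-2-yl in place of 3-methoxyphenyl gives a number 1 percentage points lower from compound 2 to compound 4 (within the scatter) and furan-2-yl in place of thiophen-2-yl gives a number 2 percentage points higher from compound 1 to compound 4 (within the scatter) and so, at this single test concentration, these three groups cannot be told apart. Of the four groups now compared on this double-bonded chain carbon, only 3,4-dimethoxyphenyl stands clear of the rest, which makes compound 3 the highest of the set and suggests that this position tolerates quite different rings without separating them until that group is present.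

The compounds shown leave open whether a plain phenyl, 4-methoxyphenyl or 3,4,5-trimethoxyphenyl ring, or a ring carrying a dimethylamino group, would match compound 3 or fall with the others. Nothing available explains why 3,4-dimethoxyphenyl stands apart.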